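Demethylation on a Pyrazole Urea Series: What Happens Next

The compounds below may be only part of what the source reports. "The series", "measured", "known", "first", "only" and "open" are said of these compounds alone.

The measured compounds and their values:

Compound 1, `COc1cc(-c2nn(-c3cccc(NC(=O)Nc4cc(C(F)(F)F)cc(C(F)(F)F)c4)c3)cc2-c2ccncc2)ccc1Cl`: 531 nM
Compound 2, `COc1cc(-c2nn(-c3cccc(NC(=O)Nc4ccc(Cl)c(Cl)c4)c3)cc2-c2ccncc2)ccc1Cl`: 811 nM
Compound 3, `O=C(Nc1cccc(-n2cc(-c3ccncc3)c(-c3ccc(Cl)c(O)c3)n2)c1)Nc1ccc(Cl)c(Cl)c1`: 1010 nM

All three were tested in a functional assay on KM12 cells (Homo sapiens) for inhibition, read by sulforhodamine B assay, with a stated time of 48 h; a higher number here means a weaker inhibitor of growth, a lower number a stronger inhibitor of growth. Compound 1 gives 531 nM; compound 2 gives 811 nM; compound 3 gives 1010 nM. The gaps between these three values all lie within the scatter of the measurement, so none of them can be called the stronger or weaker inhibitor of growth on this evidence.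

Compound 2 and compound 3 differ in one place: hydrogen in place of methyl on an oxygen on an aromatic ring. This change produced a 1.2-fold higher number from compound 2 to compound 3 (0.10 log units; within the scatter), a step that is within the scatter.

Compound 1 and compound 2 share a urea-linked pyrazole core but differ in the aryl group on the far side of the urea; the difference between the two cores is not broken down here.

The unmeasured compound 4, `O=C(Nc1cccc(-n2cc(-c3ccncc3)c(-c3ccc(Cl)c(O)c3)n2)c1)Nc1cc(C(F)(F)F)cc(C(F)(F)F)c1`, is made from compound 1 by the same change: hydrogen in place of methyl on an oxygen on an aromatic ring. The place of the change is described in the same words for both pairs, so it is the same change, now on a different core.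

Because compound 1 gives 531 nM and the same change gave a 1.2-fold higher number from compound 2 to compound 3 (0.10 log units; within the scatter), compound 4 is expected to show a step of about a 1.2-fold higher number from compound 1 to compound 4 (0.09 log units; within the scatter) in this assay. On that basis compound 4 is estimated at 650 nM, with a likely range from 300 nM to 1400 nM.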

Compound 4, concentration for 50% growth inhibition: 506 nM
Compound 4: the middle estimate sits 1.3-fold (0.11 log units) above what was measured; the range from low to high includes it.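

In this assay, swapping methoxy for hydroxy on the core of compound 1, which turns 4-chloro-3-methoxyphenyl into 4-chloro-3-hydroxyphenyl, gives a 1.0-fold lower number from compound 1 to compound 4 (0.02 log units; within the scatter), so this core shows no measurable effect from the change. Set beside the earlier step, the change behaves alike on the two cores, since the two steps cannot be told apart: the same change on two cores in this assay, a 1.2-fold higher number (0.10 log units; within the scatter) from compound 2 to compound 3 and a 1.0-fold lower number (0.02 log units; within the scatter) from compound 1 to compound 4, 1.3-fold (0.12 log units) apart, within the scatter of two such steps. Within the data shown here, this agreement is a modest result: each step is too small to read on its own, so the pairs show only that the change left the growth-inhibition number within the scatter on these two cores, and they do not show that it would do the same on a third core, or in any other test.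

What the compounds leave open is whether any replacement on that oxygen, such as an ethyl group or a longer chain, would move the number beyond the scatter, or whether an amine or a carboxylic acid in place of the hydroxy would do so. Also open, from the compounds shown here alone, is how the change would behave on cores carrying other groups on the far side of the urea, such as a single trifluoromethyl or a nitrile.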